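The source may report more compounds than this note shows. Statements on the series, on what has been measured and on what is new or still open speak of the compounds shown alone.

Measured compounds:
- compound 1 `C=CCn1c(SC/C(=N/O)c2ccccc2)nnc1-c1ccc(OC)cc1`: 57%
- compound 2 `C=CCn1c(SCC(=O)c2ccccc2)nnc1-c1ccc(OC)cc1`: 61%
- compound 3 `CCn1c(SCC(=O)c2ccccc2)nnc1-c1cc(OC)c(OC)c(OC)c1`: 59%

All three numbers come from a functional assay on the whole organism (strain albino) for inhibition, with Rattus norvegicus as the target, read by paw edema, with a stated time of 5 h, at a dose of 0.28 mmol/kg by the oral route (a lower number here means less inhibition, a higher number more inhibition at the dose given (going by the name of the read-out)), and all three sit within the usual scatter of one another, so no ranking among them is claimed. Compound 2 gives 61% in this assay. Compound 1, which carries the oxime in place of the benzoyl group, gives 57%. Compound 3, built on a different core, gives 59%.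

One change has been made on a measured pair. From compound 2 to compound 1 the difference is a group of 9 heavy atoms (7 carbon, 1 nitrogen, 1 oxygen; one six-membered aromatic ring of carbon only) in place of a group of 8 heavy atoms (7 carbon, 1 oxygen; one six-membered aromatic ring of carbon only), on a saturated chain carbon bound to a sulfur; the step it produced in this assay is a number 4 percentage points lower from compound 2 to compound 1 (within the scatter), which is within the scatter. The difference between the core of compound 2 and the core of compound 3 is not broken down here; the two values simply lie close together.

Compound 4 `CCn1c(SC/C(=N/O)c2ccccc2)nnc1-c1cc(OC)c(OC)c(OC)c1` has not yet been measured in this assay. From compound 3 to compound 4 the change is a group of 9 heavy atoms (7 carbon, 1 nitrogen, 1 oxygen; one six-membered aromatic ring of carbon only) in place of a group of 8 heavy atoms (7 carbon, 1 oxygen; one six-membered aromatic ring of carbon only), on a saturated chain carbon bound to a sulfur, placed on the same saturated chain carbon bound to a sulfur as in the earlier pair, so it is the same change applied to the other core. The expectation rests on that earlier pair: because a number 4 percentage points lower from compound 2 to compound 1 (within the scatter) was small, the step is expected to be a number 4 percentage points lower from compound 3 to compound 4 (within the scatter). For compound 4 the estimate in this assay is therefore 55%, with a range of 43% to 67%.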

Compound 4, a percentage reported as inhibition, in the whole organism at one dose (the size of the read-out at that dose, not a potency): 74%
Estimate against measurement, compound 4: 19 percentage points below; the whole stated range lies below it.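

In this assay, exchanging the benzoyl group for the oxime on the saturated chain carbon bound to a sulfur gives a number 15 percentage points higher from compound 3 to compound 4 (beyond the scatter), and this step cannot be taken as a fixed increment that carries from one core to another in this series. The two readings of the same change disagree: the same change on two cores in this assay, a number 4 percentage points lower (within the scatter) from compound 2 to compound 1 and a number 15 percentage points higher (beyond the scatter) from compound 3 to compound 4, 19 percentage points apart, beyond the scatter of two such steps

This shows that the outcome of the change depends on the core it is placed on, at least for these two pairs, but it does not show which part of the core is responsible: the core of compound 2 and the core of compound 3 differ in more than one place, and with one pair per core there is no basis for a rule covering any further core, nor for an explanation of the step itself.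

Still open, from the compounds shown here alone, is whether the difference between the two steps goes with the ethyl or allyl chain or with the methoxy groups on the aromatic ring of the core. Also open, going by these compounds, is how an amine or a methyl oxime ether on the same saturated chain carbon bound to a sulfur would read on either core.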